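A few compounds are considered here, and "the series" means these few. Any claim that something is new, unique, unknown or untested is made for them only; others in the source may bear on it.

Measured so far in a functional assay on CHO cells for agonist activity at Free fatty acid receptor 2 (Homo sapiens), read by cAMP accumulation; a higher number here means a larger maximal response, a lower number a smaller maximal response:
Compound 1, `CC(C)C(c1ccc(Cl)cc1)S(=O)(=O)Nc1nccs1`, gives < 30%; this is a limit of the assay, not a number.
Compound 2, `CC(C)[C@H](C(=O)Nc1ccccn1)c1ccc(Cl)cc1`, gives 92%.
Compound 3, `CC(C)C(C(=O)Nc1cnccn1)c1ccc(Cl)cc1`, gives 115%.

Among the two numbers in this assay, compound 2 stands lowest; compound 3 lies above it by a gap beyond the usual scatter. The third entry, compound 1, sits at a limit, as summed up in the limit of < 30% in this assay, at which 1 of the 3 values shown sits.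

The piece follows the step from compound 2 to compound 4, `CC(C)[C@H](C(=O)NC1=NC(=O)CS1)c1ccc(Cl)cc1`. Compound 4 differs from compound 2 as follows: a group of 6 heavy atoms (3 carbon, 1 nitrogen, 1 oxygen, 1 sulfur; one five-membered non-aromatic ring with 2 hetero atoms) in place of a group of 6 heavy atoms (5 carbon, 1 nitrogen; one six-membered aromatic ring with 1 hetero atom), on an amide-type nitrogen.

Among the compounds with values here, no step between measured compounds has been counted, so the size of the step in this assay can only be expected. Compound 2 and compound 3 show that two six-membered aromatic groups on the amide-type nitrogen both reach large responses, while compound 1, with a different linker, reaches only a limit. The expectation is a downward step, a number 32 percentage points lower from compound 2 to compound 4 (beyond the scatter), beyond the scatter. Compound 4 is therefore estimated to give 60% in this assay, within a range from 25% to 100%.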

Compound 4, largest response reached (reported as efficacy), in percent of the reference or control that the assay uses: 96%
Compound 4: middle estimate off by 36 percentage points, on the low side, within the range that was stated.
By their numbers in this assay, from the lowest: compounds 2 and 4 (each within the scatter of the next); then compound 3. At a limit, below all of these: compound 1.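

In this assay, putting the five-membered non-aromatic ring with 2 hetero atoms in place of pyridin-2-yl on the amide-type nitrogen gives a number 4 percentage points higher from compound 2 to compound 4 (within the scatter), so the large maximal response is kept. The earlier amides had carried only six-membered aromatic groups at this place, whereas this pair shows that, for this one change, neither an aromatic ring nor a six-membered ring is needed for such a response. Nothing among the data shown accounts for why the response holds across this change.

On these data alone, it remains open whether a simple methyl group or a chain ending in a carboxylic acid on this nitrogen would keep the response. As far as these compounds go, it is equally open whether the ring of compound 4 would still do so if a methoxy group replaced the chlorine of the shared core.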